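Swapping a methyl for a pyridinyl on the side chain

A few compounds are considered here, and "the series" means these few. Any claim that something is new, unique, unknown or untested is made for them only; others in the source may bear on it.

For the measured compounds named here, compound 2 `CCNc1nc(C)c(-c2nc3ccccc3s2)c(N[C@@H]2C[C@H](CO)[C@@H](O)[C@H]2O)n1` is one of two compounds measured in an ADME assay on cells (Homo sapiens) for cytotoxicity, read by polymerase chain reaction, with a stated time of 3 days (a higher number here means that more compound is tolerated, a lower number that less compound is tolerated), where compound 2 gives 12000 nM. Compound 1 `CNc1ccc2nc(-c3c(Cl)nc(N)nc3N[C@@H]3C[C@H](CO)[C@@H](O)[C@H]3O)sc2c1` in this assay gives 6000 nM, and the two values lie within the usual scatter of each other, so no order between them can be read. Compound 3 `Cc1nc(NCc2ccccn2)nc(N[C@@H]2C[C@H](CO)[C@@H](O)[C@H]2O)c1-c1nc2ccccc2s1` differs from compound 2 in one place: pyridin-2-yl in place of methyl on a saturated chain carbon bound to a nitrogen on an aromatic ring. Going by the values given here, no measured pair shows what this change does. The expected step of a 1.2-fold lower number from compound 2 to compound 3 (0.08 log units; within the scatter) is none beyond the scatter. Compound 3 is therefore estimated at 10000 nM, within a range from 4000 nM to 25000 nM.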

Compound 3, half-maximal cytotoxic concentration: 13000 nM
Beside the measured number, compound 3's estimate is 1.3-fold (0.11 log units) below it; the measured number falls inside the stated range.
By their numbers in this assay, from the lowest: compounds 1, 2 and 3 (each within the scatter of the next, the first and the last beyond it).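

For the compounds shown here, on this saturated chain carbon bound to a nitrogen on an aromatic ring, the first direct comparison in this assay gives a step of a 1.1-fold higher number from compound 2 to compound 3 (0.03 log units; within the scatter). Pyridin-2-yl, with its six heavy atoms and aromatic ring, therefore leaves compound 3 indistinguishable from compound 2, which carries methyl at this place. Nothing measured here offers an explanation for this result. Going by these compounds, whether a carboxylic acid, an amine or a longer chain on the same carbon would also stay within the scatter remains open.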